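Sulfonyl for carbonyl on the ring nitrogen: compound 3

A few compounds are considered here, and "the series" means these few. Any claim that something is new, unique, unknown or untested is made for them only; others in the source may bear on it.

Measured so far in a functional assay on MDA-MB-231 cells (Homo sapiens) for inhibition, read by sulforhodamine B assay, tested at 10 uM; on this read-out higher numbers stand for more inhibition at the one concentration tested (going by the name of the read-out) and lower numbers for less inhibition:
- compound 1, `CC(=O)N1N=C(c2ccc(-n3cncn3)cc2)CC1c1ccc(N(C)C)cc1`, gives 7.4%
- compound 2, `CN(C)c1ccc(C2CC(c3ccc(-n4cncn4)cc3)=NN2C(=O)/C=C/c2ccccc2)cc1`, gives 8.5%

Compound 2 holds the highest of the two numbers, but its nearest neighbour, compound 1, lies within the scatter of it, so the two are not separated. Going by the values given here, the only measured step, a number 1.1 percentage points higher from compound 1 to compound 2 (within the scatter), exchanged the group on the carbonyl carbon and left the read-out essentially where it was.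

Compound 3, `Cc1ccc(S(=O)(=O)N2N=C(c3ccc(-n4cncn4)cc3)CC2c2ccc(N(C)C)cc2)cc1`, is not yet measured. It differs from compound 2 by (4-methylphenyl)sulfonyl in place of (2-phenylethenyl)carbonyl on an amine nitrogen in a ring. Among the compounds with values here, the one known step bears on this only in part: it shows that changing what sits beyond the carbonyl on the ring nitrogen does not move this assay beyond the scatter. Within the data shown here, no measured pair exchanges the carbonyl itself for a sulfonyl, so that part of the change has no precedent here. Among the measured compounds shown here, with both measured compounds sitting low and the one relevant step flat, the expected step is a number 1.5 percentage points higher from compound 2 to compound 3 (within the scatter), that is, none beyond the scatter. Compound 3 is therefore estimated at 10%, within a range from 0% to 25%.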

Compound 3, a percentage reported as inhibition, at one concentration (the size of the read-out at that concentration, not a potency): 20.7%
Compound 3: middle estimate off by 10.7 percentage points, on the low side, and the stated range covers the measured number.
By their numbers in this assay, from the lowest: compounds 1 and 2 (each within the scatter of the next); then compound 3.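

In this assay the ring nitrogen now shows a change that separates compounds: the exchange of (2-phenylethenyl)carbonyl for (4-methylphenyl)sulfonyl gives a number 12.2 percentage points higher from compound 2 to compound 3 (beyond the scatter) and the exchange of acetyl for the same sulfonyl group gives a number 13.3 percentage points higher from compound 1 to compound 3 (beyond the scatter) on the same core. Going by these compounds alone, the earlier compounds showed only that two carbonyl-linked groups on this nitrogen are not separated, whereas the sulfonyl compound now stands apart from both of them. The entering and leaving groups in the step from the cinnamoyl-type compound match in heavy-atom count and in their one six-membered aromatic ring of carbon only, so the step does not go with either of those counts, though the groups differ in their atoms and hydrogen-bond acceptors, and nothing available here gives a reason for the step.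

The sulfonyl link and the 4-methylphenyl group entered together, so the compounds shown do not tell which of the two goes with the higher number. A 4-methylbenzoyl group or a methanesulfonyl group on the same ring nitrogen would divide the two, and the read-out at one concentration leaves potency open.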